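Swapping Naphthalene for Phenyl on the Amine Arm

The source may report more compounds than this note shows. Statements on the series, on what has been measured and on what is new or still open speak of the compounds shown alone.

Three sulfonamides sharing one core have been measured in a functional assay on MCF7 cells (Homo sapiens) for inhibition, read by MTT assay, with a stated time of 72 h; on this read-out lower numbers stand for stronger inhibition of growth and higher numbers for weaker inhibition of growth. Compound 1 `O=S(=O)(NCCCNCc1cccc2ccccc12)c1cc(C(F)(F)F)cc(C(F)(F)F)c1` gives 1400 nM, level with compound 2 `O=S(=O)(NCCCNCc1ccc(C(F)(F)F)cc1)c1cc(C(F)(F)F)cc(C(F)(F)F)c1` at 1400 nM, and together these are the lowest of the three numbers, while compound 3 `O=S(=O)(NCCCNCc1ccc(-c2ccccc2)cc1)c1cc(C(F)(F)F)cc(C(F)(F)F)c1` gives 1700 nM. Compound 4 `O=S(=O)(NCCCNCc1ccccc1)c1cc(C(F)(F)F)cc(C(F)(F)F)c1` is not yet measured; it differs from compound 1 by phenyl in place of naphthalen-1-yl on a saturated chain carbon bound to an amine nitrogen. Among the compounds with values here, two measured steps bear on this change. no change at the digits printed from compound 1 to compound 2 (within the scatter) shows that putting 4-(trifluoromethyl)phenyl in the place of naphthalen-1-yl left the number where it was, and a 1.2-fold higher number from compound 2 to compound 3 (0.08 log units; within the scatter) shows a similar indifference to the group carried on that aryl ring. Little movement beyond the scatter is therefore expected for compound 4, a 1.4-fold higher number from compound 1 to compound 4 (0.15 log units; within the scatter). Compound 4 is estimated to give 2000 nM, between 900 nM and 5000 nM.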

Compound 4, concentration for 50% growth inhibition: 3000 nM
Compound 4: the middle estimate sits 1.5-fold (0.18 log units) below what was measured, within the range that was stated.
By their numbers in this assay, from the lowest: compounds 1, 2, 3 and 4 (each within the scatter of the next, the first and the last beyond it).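

Within the data shown here, the bare phenyl ring is the first change on this arm to pass the scatter: naphthalen-1-yl gives way to phenyl with a 2.1-fold higher number from compound 1 to compound 4 (0.33 log units; beyond the scatter) and trifluoromethyl gives way to hydrogen with a 2.1-fold higher number from compound 2 to compound 4 (0.33 log units; beyond the scatter), both modest steps. In this assay, removing the phenyl group instead gives a 1.8-fold higher number from compound 3 to compound 4 (0.25 log units; within the scatter), so the ring's added carbon groups count only modestly, and this last step does not separate the two compounds. Nothing measured here explains these shifts.

Still open, as far as these compounds go, is whether a methoxy group or a chlorine on the aryl ring would behave like trifluoromethyl. A longer chain in the shared core also remains untested in the compounds shown.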